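Reversing the Enone Link on a Weakly Active Core

The source may hold more compounds than are shown below. What is called first, only, known or untested is meant among the compounds shown, and "the series" means these compounds.

Measured compounds:
compound 1 `COc1ccc(/C=C/C(=O)c2cc(-c3ccc(OC)c(OC)c3)n3nc(-c4ccccc4)cc3n2)cc1`: 50700 nM
compound 2 `COc1cc(-c2cc(C(=O)/C=C/c3ccccc3)nc3cc(-c4ccccc4)nn23)cc(OC)c1OC`: 44800 nM

In an ADME assay on HEK293 cells (Homo sapiens) for antiproliferative activity, read by MTT assay, with a stated time of 24 h (on this read-out lower numbers stand for stronger inhibition and higher numbers for weaker inhibition), compound 1 gives 50700 nM, and compound 2 gives 44800 nM. Compound 1 has the higher of the two numbers, yet its gap to compound 2 lies within the scatter, so the two cannot be ranked. Compound 3 `COc1ccc(-c2cc(/C=C/C(=O)c3ccc(C)cc3)nc3cc(-c4ccccc4)nn23)cc1OC` differs from compound 1 by 2-((4-methylphenyl)carbonyl)ethenyl in place of (2-(4-methoxyphenyl)ethenyl)carbonyl on an aromatic carbon. For the measured compounds named here, no measured pair isolates this change, so the expected step from compound 1 to compound 3, a 1.1-fold lower number from compound 1 to compound 3 (0.05 log units; within the scatter), is estimated to stay within the scatter. Compound 3 is therefore expected at 45000 nM, between 18000 nM and 110000 nM.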

Compound 3, half-maximal inhibitory concentration: 62600 nM
Beside the measured number, compound 3's estimate is 1.4-fold (0.14 log units) below it, and the stated range covers the measured number.
By their numbers in this assay, from the lowest: compounds 2, 1 and 3 (each within the scatter of the next).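

In this assay, 2-((4-methylphenyl)carbonyl)ethenyl in place of (2-(4-methoxyphenyl)ethenyl)carbonyl on this aromatic carbon gives a 1.2-fold higher number from compound 1 to compound 3 (0.09 log units; within the scatter), so the two groups cannot be told apart here. This one swap both reverses the enone link and trades methoxy for methyl on the aromatic ring, and the read-out separates neither edit. Still open, from the compounds shown here alone, is whether either edit alone, or an amine or a carboxylic acid on that ring, would give a number clearly different from these. No measurement at hand bears on this result.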